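Methoxy in Place of Trifluoromethyl: Expected Cytotoxicity

The compounds below may be only part of what the source reports. "The series", "measured", "known", "first", "only" and "open" are said of these compounds alone.

Of the compounds shown here, three have so far been measured in an ADME assay on Huh-7 cells (Homo sapiens) for cytotoxicity; on this read-out higher numbers stand for lower toxicity in this test and lower numbers for higher toxicity in this test. Compound 1 `Cc1ccccc1-c1nn(-c2cccc(Cl)c2)cc1CNCCN1CCN(C)CC1` gives 16000 nM, compound 2 `Cc1ccccc1-c1nn(-c2ccc(C(F)(F)F)cc2)cc1CNCCN1CCN(C)CC1` gives 11000 nM, and compound 3 `CN1CCN(CCCNCc2cn(-c3ccc(C(F)(F)F)cc3)nc2-c2ccc(C(F)(F)F)cc2)CC1` gives 2000 nM. Compound 2 stands second highest of the three; its nearest neighbour is compound 1, whose value lies within the scatter of its own, while compound 3 lies well below it, beyond the scatter.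

Compound 4 `COc1ccc(-n2cc(CNCCN3CCN(C)CC3)c(-c3ccccc3C)n2)cc1` has not yet been measured. It differs from compound 2 in one place: methoxy in place of trifluoromethyl on an aromatic carbon.

Among the measured compounds shown here, only one measured step concerns the ring on the aromatic nitrogen: a 1.5-fold lower number from compound 1 to compound 2 (0.16 log units; within the scatter). That exchange of one group for another on the same ring stayed within the scatter. For the measured compounds named here, compound 2 and compound 3 are not connected by a single-point step, so their values show only that compound 3 carries the lower number. On this basis no shift beyond the scatter is expected from compound 2 to compound 4, and the estimated step is a 1.3-fold higher number from compound 2 to compound 4 (0.10 log units; within the scatter). Compound 4 is therefore expected to give about 14000 nM, within a range from 6000 nM to 32000 nM.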

Compound 4, half-maximal cytotoxic concentration: > 20000 nM
Compound 4 gave a limit, no number; the forecaster's own chance of this, stated with the estimate: 10%; middle value at least 1.4-fold (0.15 log units) away from the limit.
By their numbers in this assay, from the lowest: compound 3; then compounds 2 and 1 (each within the scatter of the next). At a limit, above all of these: compound 4.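

In this assay compound 4 stays at a limit and gives no number: the limit of > 20000 nM in this assay, at which 1 of the 4 values shown sits. The change of methoxy for trifluoromethyl on this aromatic carbon, para to a large group, gives an at least 1.8-fold higher number from compound 2 to compound 4 (0.25 log units; that floor lies within the scatter), and the change of the whole group on the aromatic nitrogen gives an at least 1.2-fold higher number from compound 1 to compound 4 (0.09 log units; that floor lies within the scatter). Until now this position had carried only 3-chlorophenyl and 4-(trifluoromethyl)phenyl, and compound 4 shows that a group with a hydrogen-bond acceptor can sit here with no fall in the number, although both floors lie within the scatter and so show no clear rise either.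

On these data alone, how far compound 4 lies past its limit remains unknown, so it stays open whether methoxy truly differs from trifluoromethyl here by more than the scatter. Also open, as far as these compounds go, are how an amine or a carboxylic acid would read on this aromatic carbon, and whether methoxy would act the same way on the core of compound 3, with its longer chain and its second 4-(trifluoromethyl)phenyl.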